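This account rests on a few compounds, and the source may have more. Where it says the series, first, only, none or still open, it means among the compounds named here.

Working notes on the series.

Compound 1 `C[C@]1(CN2CCc3nc(C4CCCCC4)ccc3C2)Cn2cc([N+](=O)[O-])nc2O1` and compound 2 `C[C@]1(CN2CCc3nc(N4CCC(F)(F)CC4)ccc3C2)Cn2cc([N+](=O)[O-])nc2O1` share the core of compound 3 `C[C@]1(CN2CCc3nc(-c4ccccc4F)ccc3C2)Cn2cc([N+](=O)[O-])nc2O1`; in an ADME assay on Vero cells (Chlorocebus sabaeus) for cytotoxicity, read by MTT assay, with a stated time of 72 h (a higher number here means that more compound is tolerated, a lower number that less compound is tolerated), compound 1 gives "not determined" (no result reported), and in this assay compound 2 likewise gives "not determined" (no result reported), so neither contributes a number. Among the compounds with values here, compound 3 is the only member of the set with an entry in this assay, and that entry is a limit rather than a number: compound 3 gives > 32 ug/mL. Within the data shown here, this is the same limit as the limit of > 32 ug/mL in this assay, at which 1 of the 3 values shown sits, so the standing of compound 3 is known only as lying at or beyond that boundary; no step between two measured compounds exists within the set.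

Compound 4 `C[C@]1(CN2CCc3nc(-c4ccc(F)c(F)c4)ccc3C2)Cn2cc([N+](=O)[O-])nc2O1` differs from compound 3 by 3,4-difluorophenyl in place of 2-fluorophenyl on an aromatic carbon. Among the measured compounds shown here, no measured step informs the size of the change in this assay, so no shift beyond the usual scatter is expected in either direction; the estimated step from compound 3 to compound 4 is a step that the limit leaves unreadable from compound 3 to compound 4. Compound 4 is therefore expected to give about 40 ug/mL in this assay, with a plausible range from 20 ug/mL to 80 ug/mL, and it is likely that the assay again reports only a limit rather than a number.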

Compound 4, half-maximal cytotoxic concentration: > 32 ug/mL
Compound 4 ended at the assay's limit (the forecaster's own chance of this, stated with the estimate: 75%); the middle value does not contradict the limit.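

No step from compound 3 to compound 4 can be read in this assay, because both entries are limits of the assay and not numbers: the limit of > 32 ug/mL in this assay, at which 2 of the 4 values shown sit.

The compounds shown leave open where compound 3 and compound 4 actually stand in this assay, and whether 3,4-difluorophenyl in place of 2-fluorophenyl shifts the read-out at all.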